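The source may hold more compounds than are shown below. What is called first, only, known or untested is meant among the compounds shown, and "the series" means these compounds.

Three compounds share one core, and all have been tested in an assay on isolated protein for binding affinity to Equilibrative nucleoside transporter 1 (Homo sapiens); a lower number here means a stronger inhibitor, a higher number a weaker inhibitor. Compound 1, `CCSc1ncnc2c1ncn2[C@@H]1O[C@H](CO)[C@@H](O)[C@H]1O`, gives 57500 nM. Compound 2, `Cc1ccc(CSc2ncnc3c2ncn3[C@@H]2O[C@H](CO)[C@@H](O)[C@H]2O)cc1`, gives 457 nM. Compound 3, `OC[C@H]1O[C@@H](n2cnc3c(CSc4ccccc4I)ncnc32)[C@H](O)[C@@H]1O`, gives 282 nM, the lowest of the three numbers; its step to compound 2 lies within the scatter, while its step to compound 1 lies far beyond it. The measured steps show a 130-fold lower number from compound 1 to compound 2 (2.10 log units; beyond the scatter) and a 200-fold lower number from compound 1 to compound 3 (2.31 log units; beyond the scatter), but only a 1.6-fold lower number from compound 2 to compound 3 (0.21 log units; within the scatter).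

Compound 4, `COC(=O)c1ccc(SCc2ncnc3c2ncn3[C@@H]2O[C@H](CO)[C@@H](O)[C@H]2O)cc1`, is not yet measured. It differs from compound 3 in one place: 4-(methoxycarbonyl)phenyl in place of 2-iodophenyl on a sulfur. Within the data shown here, the only step that bears on this change is the exchange of one aryl group for another, from compound 2 to compound 3, which stayed within the scatter. Compound 4 is therefore expected to show no step beyond the scatter, with a 1.4-fold higher number from compound 3 to compound 4 (0.15 log units; within the scatter). The estimate for compound 4 in this assay is 400 nM, in a range from 150 nM to 1500 nM.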

Compound 4, half-maximal inhibitory concentration: 813 nM
Beside the measured number, compound 4's estimate is 2.0-fold (0.31 log units) below it; measured number inside the range.
By their numbers in this assay, from the lowest: compounds 3, 2 and 4 (each within the scatter of the next, the first and the last beyond it); then compound 1.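

In this assay, the exchange on the sulfur whose other neighbour is a saturated chain carbon does change the number, with a 2.9-fold higher number from compound 3 to compound 4 (0.46 log units; beyond the scatter), a modest step, whereas the earlier exchange of one aryl group for another gave only a 1.6-fold lower number from compound 2 to compound 3 (0.21 log units; within the scatter). The choice of aryl group on this sulfur therefore matters to a small degree, even though a six-membered aromatic ring of carbon only is present on both sides of the step. Nothing measured alongside these numbers accounts for the step.

The compounds shown do not separate the departure of the iodine from the arrival of the methoxycarbonyl group, and a plain phenyl or a 4-iodophenyl group on the sulfur would bear on that. They also leave open how a carboxylic acid or an amide in place of the methyl ester would read in this assay.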